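Replacing Hydroxy by Trifluoromethyl on the Sulfonyl Aryl Ring

The source may hold more compounds than are shown below. What is called first, only, known or untested is meant among the compounds shown, and "the series" means these compounds.

Three sulfonamides built on one shared core have been tested in an assay on cells for inhibition of HSP60/HSP10 (Homo sapiens), with a stated time of 60 min; a higher number here means a weaker inhibitor, a lower number a stronger inhibitor. Compound 1 `Cc1ccc(S(=O)(=O)Nc2ccc(-c3nc4ccccc4o3)cc2)cc1` reaches only the limit of the assay, > 100000 nM, so no number is available for it (the limit of > 100000 nM in this assay, at which 1 of the 3 values shown sits). Compound 2 `O=S(=O)(Nc1ccc(-c2nc3ccccc3o2)cc1)c1cccc(O)c1` gives 62000 nM in this assay, and compound 3 `O=S(=O)(Nc1ccc(-c2nc3ccccc3o2)cc1)c1ccc(O)cc1` gives 78000 nM. Compound 3 thus stands beside compound 2 among the two numbers shown, and the step of a 1.3-fold higher number from compound 2 to compound 3 (0.10 log units; within the scatter) is within the scatter, so the two cannot be told apart. The step of an at least 1.2-fold lower number from compound 1 to compound 3 (0.10 log units; that floor lies within the scatter) rests on a limit and its floor also lies within the scatter.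

Compound 4 `O=S(=O)(Nc1ccc(-c2nc3ccccc3o2)cc1)c1ccc(C(F)(F)F)cc1` differs from compound 3 by trifluoromethyl in place of hydroxy on an aromatic carbon, in words a trifluoromethyl in place of hydroxy on an aromatic carbon. Among the measured compounds shown here, the only measured step bearing on this change is the one in which methyl gave way to hydroxy on an aromatic carbon, where the number moved an at least 1.2-fold lower number from compound 1 to compound 3 (0.10 log units; that floor lies within the scatter); compound 4 removes that hydroxy again. No step beyond the scatter is seen across these three compounds. Compound 4 is therefore expected to sit near compound 3 or somewhat higher, a 1.3-fold higher number from compound 3 to compound 4 (0.11 log units; within the scatter). The estimate for compound 4 is 100000 nM, with a range from 40000 nM to 250000 nM, and a fair chance that only a limit is reported.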

Compound 4, half-maximal inhibitory concentration: 50000 nM
Estimate against measurement, compound 4: 2.0-fold (0.30 log units) above, and the stated range covers the measured number.
By their numbers in this assay, from the lowest: compounds 4, 2 and 3 (each within the scatter of the next). At a limit, above all of these: compound 1.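

In this assay, trifluoromethyl in place of hydroxy on the aromatic carbon para to a large group gives a 1.6-fold lower number from compound 3 to compound 4 (0.19 log units; within the scatter), so compound 3 and compound 4 cannot be told apart even though the one hydrogen-bond donor and one hydrogen-bond acceptor of the hydroxy have left. Among the compounds shown here, a measurable value at this position therefore does not depend on a hydroxy, which the earlier compounds could not show, as both of their numbers came from hydroxy compounds. Trifluoromethyl in place of methyl gives an at least 2.0-fold lower number from compound 1 to compound 4 (0.30 log units; that floor lies within the scatter), so even this widest step does not establish a difference beyond the scatter, and compound 1 remains a limit, not a number: the limit of > 100000 nM in this assay, at which 1 of the 4 values shown sits.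

Whether an amine, a carboxylic acid or a longer chain on this aromatic carbon would move the number beyond the scatter remains open, and nothing shown here separates the groups that gave numbers from one another. The compounds also leave open how far changes to the shared core itself would shift the number, as all of them vary only on the sulfonyl aryl ring.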